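A few compounds are considered here, and "the series" means these few. Any claim that something is new, unique, unknown or untested is made for them only; others in the source may bear on it.

Compound 3 `COc1ccc(-c2cnc(NC(=O)c3ccc(O)cc3)n2C)cc1` is one of three compounds tested in a toxicity assay on THP-1 cells (Homo sapiens) for inhibition; a higher number here means that more compound is tolerated, a lower number that less compound is tolerated. In this assay compound 3 gives only a limit of the assay, > 100000 nM. Compound 1 `COc1ccc(-c2cnc(NC(=O)c3cccc(OC)c3)n2C)cc1` likewise reaches only a limit, > 100000 nM. Compound 2 `CCCC(=O)Nc1ncc(-c2ccc(OC)cc2)n1C` also stops at a limit, > 100000 nM. Because all three sit at the limit of > 100000 nM in this assay, at which 3 of the 3 values shown sit, the steps a step that the two limits leave unreadable from compound 1 to compound 2, a step that the two limits leave unreadable from compound 1 to compound 3 and a step that the two limits leave unreadable from compound 2 to compound 3 cannot be sized. Compound 4 `COc1ccc(-c2cnc(NC(=O)c3ccc(Br)cc3)n2C)cc1` differs from compound 3 in one place: bromo in place of hydroxy on an aromatic carbon. For the measured compounds named here, no measured step touches this change, and none can be sized, so no direction beyond the scatter can be read for compound 4 in this assay. Compound 4 is expected to stay at the limit, an estimated step of a number no higher from compound 3 to compound 4 (the limit leaves the size open). The estimate for compound 4 in this assay is 100000 nM, between 40000 nM and 300000 nM.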

Compound 4, half-maximal cytotoxic concentration: > 100000 nM
Compound 4: a limit, no number (the forecaster's own chance of this, stated with the estimate: 80%); the middle value sits exactly at the limit.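

In this assay, for the compounds shown here, compound 4 gives only a limit, > 100000 nM and no step to it from compound 1, compound 2 or compound 3 can be read, because all four share that limit: the limit of > 100000 nM in this assay, at which 4 of the 4 values shown sit.

The compounds shown leave open how much of any of them is tolerated, and whether any change on the carbonyl carbon or the aromatic carbon alters it.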